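A Larger Group on Compound 2: What to Expect

This account rests on a few compounds, and the source may have more. Where it says the series, first, only, none or still open, it means among the compounds named here.

Measured in an ADME assay on HEK-293T cells (Homo sapiens) for inhibition, read by luminescence, with a stated time of 72 h, tested at 5 uM; a lower number here means less inhibition of growth, a higher number more inhibition of growth at the concentration tested:
- compound 1 `C=CS(=O)(=O)NC/C=C/c1cc(OC)cc(O)c1C(=O)OCC1CCCCC1`: 31.2%
- compound 2 `COc1cc(O)c(C(=O)OC(C)C)c(/C=C/CN2C(=O)C=CC2=O)c1`: 8%

For the measured compounds named here, with only two compounds measured, the comparison is simple. Compound 2 has the lower number, and its gap to compound 1 lies beyond the usual scatter of repeated measurements. These cells are therefore held back less by compound 2 than by compound 1 at the concentration tested.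

The next compound to be tested is compound 3 `COc1cc(O)c(C(=O)OCC2CCCCC2)c(/C=C/CN2C(=O)C=CC2=O)c1`. It differs from compound 2 in one place, with cyclohexylmethyl in place of isopropyl on an oxygen next to a carbonyl group.

Going by the values given here, no two measured compounds differ in only one place, so the data give no direct measure of what a single change does here. Among the compounds with values here, the one guide is compound 1 at 31.2%, which shows that clearly higher values occur in this small set. A modest rise in this assay is therefore expected, though it may not clear the scatter. The estimated change is a number 12 percentage points higher from compound 2 to compound 3 (beyond the scatter). For compound 3 the estimated value is 20%, with an expected range of 5% to 45%.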

Compound 3, percent growth inhibition at one concentration: 6.9%
Compound 3: the middle estimate sits 13.1 percentage points above what was measured; the range from low to high includes it.
By their numbers in this assay, from the lowest: compounds 3 and 2 (each within the scatter of the next); then compound 1.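

For the compounds shown here, at this position, the first direct reading of a single change in this assay gives a number 1.1 percentage points lower from compound 2 to compound 3 (within the scatter): cyclohexylmethyl in place of isopropyl on an oxygen next to a carbonyl group leaves the two compounds indistinguishable, even though the group entering has 7 heavy atoms and a six-membered ring, and the group leaving has 3 heavy atoms and no ring. Going by these compounds alone, the other new step gives a number 24.3 percentage points lower from compound 1 to compound 3 (beyond the scatter) and is the first to isolate a different part of the molecule, as both compounds carry cyclohexylmethyl and differ only in the group on a saturated chain carbon bound to a double-bonded chain carbon. Cyclohexylmethyl alone therefore does not carry the higher number of compound 1, and in this small set that number goes with the sulfur-containing group of 6 heavy atoms rather than the five-membered ring group of 7 heavy atoms.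

No measurement available here offers an explanation for either step. Open questions are whether a benzyl group or a longer chain on that oxygen would read differently, and whether isopropyl paired with the sulfur-containing group would give a number near that of compound 1.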